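A few compounds are considered here, and "the series" means these few. Any claim that something is new, unique, unknown or untested is made for them only; others in the source may bear on it.

Series notes, tolerability in a toxicity assay on THP-1 cells (Homo sapiens) for inhibition; a lower number here means that less compound is tolerated, a higher number that more compound is tolerated.

Of the compounds shown here, three have been measured. Compound 1 `COc1ccc2nc(NC(=O)c3ccc(F)cc3)n(C)c2c1` carries no ring on the carbon bearing the methyl-substituted nitrogen; in this assay compound 1 gives > 100000 nM, which is a limit of the assay and not a number. Compound 2 `COc1cccc(-c2cnc(NC(=O)c3ccc(F)cc3)n2C)c1` sits at the same point: in this assay compound 2 gives > 100000 nM, again a limit. Compound 3 `COc1ccc(-c2cnc(NC(=O)c3ccccc3OC)n2C)cc1` is the reference for the step followed here. In this assay compound 3 gives > 100000 nM, also a limit. Within the data shown here, compound 3 therefore stands together with the other two values at the limit of > 100000 nM in this assay, at which 3 of the 3 values shown sit; no numbered value separates any of the three, and no step between measured compounds can be computed.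

Compound 4 `CCC(=O)Nc1ncc(-c2ccc(OC)cc2)n1C` is not yet measured. Compared with compound 3 the change is ethyl in place of 2-methoxyphenyl on a carbonyl carbon. Among the measured compounds shown here, because compound 3 sits at the limit of > 100000 nM in this assay, at which 3 of the 3 values shown sit, with no measured step to lean on, the step from compound 3 to compound 4 is expected to be a step that the limit leaves unreadable from compound 3 to compound 4, none beyond the scatter. For compound 4 the expected value in this assay is 150000 nM, with a range from 50000 nM to 500000 nM, most probably reported once more only as a limit.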

Compound 4, half-maximal cytotoxic concentration: > 100000 nM
Compound 4: a limit, no number; the forecaster's own chance of this, stated with the estimate: 85%; the middle value does not contradict the limit.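

No new step can be read for compound 3 and compound 4, as ethyl in place of 2-methoxyphenyl on a carbonyl carbon leaves both values as limits, not numbers: the limit of > 100000 nM in this assay, at which 4 of the 4 values shown sit.

The compounds shown leave open whether any change in this series alters tolerability in this assay.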